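A few compounds are considered here, and "the series" means these few. Any claim that something is new, unique, unknown or untested is made for them only; others in the source may bear on it.

Series notes. Compound 1 `COc1cc(OC)c(/C=C/S(=O)(=O)Cc2ccc(C#N)cc2)c(OC)c1` and compound 2 `COc1ccc(CS(=O)(=O)/C=C/c2ccc(OC)cc2OC)cc1` share the same core and differ in the substituent on one aromatic ring and in the methoxy pattern on the other. In a functional assay on DU-145 cells (Homo sapiens) for antiproliferative activity, read by trypan blue exclusion (a higher number here means a weaker inhibitor, a lower number a stronger inhibitor), compound 1 gives 7500 nM. In this assay compound 2 gives > 20000 nM, which is a limit of the assay and not a measured number. Compound 2 therefore stands at the limit of > 20000 nM in this assay, at which 1 of the 2 values shown sits, the weaker end of the two values available. Among the compounds with values here, no two measured compounds differ in a single place, so no measured step exists in this set.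

Compound 3 `COc1ccc(CS(=O)(=O)/C=C/c2c(OC)cc(OC)cc2OC)cc1` is the next entry and differs from compound 2 by methoxy in place of hydrogen on an aromatic carbon. Compound 1 carries the same methoxy pattern on that ring and gives 7500 nM, which indicates the pattern is compatible with a measurable value. The step from compound 2 to compound 3 is expected to be an at least 2.0-fold lower number from compound 2 to compound 3 (0.30 log units; that floor lies within the scatter), a gain beyond the scatter. For compound 3 the estimate is 10000 nM, expected between 3000 nM and 30000 nM, with a fair chance that only a limit is returned again.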

Compound 3, half-maximal inhibitory concentration: 25 nM
Compound 3: middle estimate off by 400-fold (2.60 log units), on the high side; measured number outside the range, below it.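

Methoxy in place of hydrogen on an aromatic carbon, ortho to a large group, gives an at least 800-fold lower number from compound 2 to compound 3 (2.90 log units; beyond the scatter) in this assay, so this one position separates a compound with no measured value from a highly active one. That step is a floor and not an exact size, with compound 2 standing at a limit of the assay and not at a number: the limit of > 20000 nM in this assay, at which 1 of the 3 values shown sits.
With this methoxy pattern held fixed, the substituent on the other aromatic ring also carries a large share of the activity, as methoxy in place of cyano gives a 300-fold lower number from compound 1 to compound 3 (2.48 log units; beyond the scatter).

Whether the gain at either place needs methoxy itself stays open, as the compounds shown carry no other group there, such as a hydroxyl, an amine, or a longer chain like ethoxy. Each of the two changes is also seen only once, so the compounds shown cannot tell whether the effect at one ring holds when the substituent on the other ring is different.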